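Swapping One Side Group on a Shared Core

The compounds below may be only part of what the source reports. "The series", "measured", "known", "first", "only" and "open" are said of these compounds alone.

Measured in a functional assay on HeLa cells (Homo sapiens) for inhibition, read by MTT assay, with a stated time of 48 h; on this read-out higher numbers stand for weaker inhibition and lower numbers for stronger inhibition:
- compound 1 `CCOC(=O)C1=C(NN=C(C#N)C#N)Nc2[nH]nc(C)c2C1c1ccc(N(C)C)cc1`: 15200 nM
- compound 2 `CCOC(=O)C1=C(N/C=N/c2ncc(-c3ccccc3)s2)Nc2[nH]nc(C)c2C1c1ccc(N(C)C)cc1`: 15400 nM
- compound 3 `CCOC(=O)C1=C(N/N=C(/Cl)c2ccc([N+](=O)[O-])cc2)Nc2[nH]nc(C)c2C1c1ccc(N(C)C)cc1`: 46200 nM

Of these three numbers, compound 3 has the highest, 46200 nM, and so shows the weakest inhibition. Its gaps to compound 1 and to compound 2 both lie beyond the usual scatter, while those two sit within the scatter of each other.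

The next molecule, compound 4 `CCOC(=O)C1=C(N/C=N/c2ccc(C)cc2)Nc2[nH]nc(C)c2C1c1ccc(N(C)C)cc1`, keeps the shared core and changes one group: a group of 9 heavy atoms (8 carbon, 1 nitrogen; one six-membered aromatic ring of carbon only) in place of a group of 12 heavy atoms (7 carbon, 2 nitrogen, 2 oxygen, 1 chlorine; one six-membered aromatic ring of carbon only), on an amine nitrogen. Among the measured compounds shown here, the only measured step between compounds that differ in one place is a 3.0-fold higher number from compound 1 to compound 3 (0.48 log units; beyond the scatter). That step brought in the very group that now leaves, and the number rose by a modest amount. For the measured compounds named here, no measured step makes this exact swap. The closest guide is compound 2, at 15400 nM, which has the same linking unit on the amine nitrogen as compound 4 but a different group at its end. A modest fall in this assay therefore seems likely, meaning somewhat stronger inhibition. The expected change is a 2.3-fold lower number from compound 3 to compound 4 (0.36 log units; beyond the scatter). For compound 4 the estimated value is 20000 nM, with an expected range of 8000 nM to 45000 nM.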

Compound 4, half-maximal inhibitory concentration: 43200 nM
Compound 4: the middle estimate sits 2.2-fold (0.33 log units) below what was measured; low and high end bracket the measured number.
By their numbers in this assay, from the lowest: compounds 1 and 2 (each within the scatter of the next); then compounds 4 and 3 (each within the scatter of the next).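

In this assay, the group with 9 heavy atoms that carries a ring and enters on the amine nitrogen gives a 1.1-fold lower number from compound 3 to compound 4 (0.03 log units; within the scatter) in place of the group with 12 heavy atoms, so this swap cannot be told apart from no change, even though the two groups differ in size and in their double bonds. The end of the chain still counts, since 4-methylphenyl in place of 5-phenyl-1,3-thiazol-2-yl on the double-bonded nitrogen gives a 2.8-fold higher number from compound 2 to compound 4 (0.45 log units; beyond the scatter) and thus a modest rise with the linking unit kept. The result also adds a second group that reads above the starting group, with a 2.8-fold higher number from compound 1 to compound 4 (0.45 log units; beyond the scatter) matching in size the earlier 3.0-fold higher number from compound 1 to compound 3 (0.48 log units; beyond the scatter). Compounds 3 and 4 thus form a higher pair, though compound 2 goes against any rule that a ring-bearing group raises the number.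

No supporting data accompany these gaps to explain them. On these data alone, how a 4-aminophenyl or a 4-carboxyphenyl group on the double-bonded nitrogen would read in this assay also stays open.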